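The source may report more compounds than this note shows. Statements on the series, on what has been measured and on what is new or still open speak of the compounds shown alone.

Compound 1 `CCC1C(=O)N(C)c2cnc(Nc3ccc(S(=O)(=O)NCC(C)C)cc3)nc2N1c1ccn(C)n1`: 311 nM
Compound 2 `CCC1C(=O)N(C)c2cnc(-n3ccc4cc(C(=O)NC(C)C)ccc43)nc2N1c1ccn(C)n1`: 125 nM

Of the compounds shown here, two have been measured so far. In an assay for inhibition of serine/threonine-protein kinase PLK2 (Homo sapiens), read by FRET and Z'-LYTE, with a stated time of 1 h (a lower number here means a stronger inhibitor, a higher number a weaker inhibitor), compound 1 gives 311 nM, the highest of the two numbers. Compound 2 gives 125 nM, a lower number, and the gap between the two lies beyond the usual scatter. Among the measured compounds shown here, no single-point step between measured compounds exists in this set, so no measured pair shows how a small change on the sulfonamide substituent moves the number.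

Compound 3 `CCCCNS(=O)(=O)c1ccc(Nc2ncc3c(n2)N(c2ccn(C)n2)C(CC)C(=O)N3C)cc1` is the next compound to be measured. It differs from compound 1 in one place: propyl in place of isopropyl on a saturated chain carbon bound to a sulfonamide nitrogen. The change keeps the same atoms and only joins them differently, so the step of a 1.0-fold lower number from compound 1 to compound 3 (0.02 log units; within the scatter) is expected to be small, in either direction, and most likely within the scatter. Compound 3 is therefore expected to give about 300 nM, with a range from 120 nM to 750 nM.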

Compound 3, half-maximal inhibitory concentration: 191 nM
Compound 3: the middle estimate sits 1.6-fold (0.20 log units) above what was measured, and the stated range covers the measured number.
By their numbers in this assay, from the lowest: compounds 2, 3 and 1 (each within the scatter of the next, the first and the last beyond it).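

In this assay, the set now holds its first step that changes one place: propyl in place of isopropyl on a saturated chain carbon bound to a sulfonamide nitrogen gives a 1.6-fold lower number from compound 1 to compound 3 (0.21 log units; within the scatter). Rearranging the isobutyl chain into a butyl chain at this position therefore leaves the number within the usual scatter, so the branched and straight chains cannot be told apart here on this single pair. Nothing available bears on why the number behaves this way.

As far as these compounds go, it remains open whether a shorter chain such as ethyl, a longer chain such as hexyl, a cyclopropyl ring, or an amine or carboxylic acid at the end of the chain would also leave the number within the scatter. One pair also cannot say whether the same swap would read alike on another core.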